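Swapping Bromo for Cyclopropyl on the Benzyl Ring

The source may report more compounds than this note shows. Statements on the series, on what has been measured and on what is new or still open speak of the compounds shown alone.

Measured compounds:
compound 1 `CC(C)(C)c1ccc(CNC(=O)C2(c3ccc(NS(C)(=O)=O)cc3)CC2)cc1`, 610 nM
compound 2 `CC(C(=O)NCc1ccc(Br)cc1)c1ccc(NS(C)(=O)=O)c(F)c1`, 412 nM

Of the compounds shown here, two have been measured in an assay on CHO cells for displacement of a labelled ligand from transient receptor potential cation channel subfamily V member 1 (Rattus norvegicus); on this read-out higher numbers stand for weaker inhibition and lower numbers for stronger inhibition. Compound 1 gives 610 nM, and compound 2 gives 412 nM. Compound 2 has the lower of the two numbers, but its distance from compound 1 lies within the usual scatter of this assay, so no order between the two can be read from these values.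

Compound 3 `CC(C(=O)NCc1ccc(C2CC2)cc1)c1ccc(NS(C)(=O)=O)c(F)c1` has not yet been measured. It differs from compound 2 in one place: cyclopropyl in place of bromo on an aromatic carbon. The group that leaves and the group that enters are both without hydrogen-bond donors or acceptors and without net charge; the change is therefore a replacement of one neutral substituent by another on the same aromatic carbon, para to a large group.

Going by the values given here, no measured pair in this set shows such a change, so nothing in the data tells how large a step to expect. The step of a 1.2-fold higher number from compound 2 to compound 3 (0.08 log units; within the scatter) is expected to stay within the scatter of this assay, in no clear direction. Compound 3 is estimated at 500 nM, within a range from 150 nM to 1700 nM.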

Compound 3, inhibition constant: 411 nM
Beside the measured number, compound 3's estimate is 1.2-fold (0.09 log units) above it; the range from low to high includes it.
By their numbers in this assay, from the lowest: compounds 3, 2 and 1 (each within the scatter of the next).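

In this assay, going by these compounds alone, the step of a 1.0-fold lower number from compound 2 to compound 3 (0.00 log units; within the scatter) gives the first reading at this position: with cyclopropyl in place of bromo on an aromatic carbon, para to a large group, the two numbers cannot be told apart. Within the data shown here, a group of three carbon atoms carrying a three-membered ring thus takes the place of a single bromine with no step that can be read, something the earlier compounds could not show, as compound 1 and compound 2 do not form a pair differing in one place. Nothing available bears on why these two groups read alike, so the result stands without an explanation.

On these data alone, both the group that leaves and the group that enters have no hydrogen-bond donors or acceptors and no net charge, so what an amine or a carboxylic acid would do on the same aromatic carbon remains open. As far as these compounds go, it is also open whether a longer chain of carbon atoms at this place would still fall within the scatter of compound 2, or would move the number clearly in either direction.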